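A few compounds are considered here, and "the series" means these few. Any claim that something is new, unique, unknown or untested is made for them only; others in the source may bear on it.

Compound 1 `Cc1ccc(S(=O)(=O)Nc2cccc(-c3nc(-c4ccc(NC(=O)c5cccnc5)cc4Cl)no3)c2)cc1`: > 10000 nM
Compound 2 `CC(=O)Nc1ccc(S(=O)(=O)Nc2cccc(-c3nc(-c4ccc(NC(=O)c5cccnc5)cc4Cl)no3)c2)cc1`: 2500 nM
Compound 3 `CC(=O)Nc1ccc(S(=O)(=O)Nc2cccc(-c3nc(-c4ccc(NC(=O)c5cccnc5)cc4Cl)no3)c2)cc1Cl`: > 10000 nM

All three compounds share a core and were tested in a functional assay on MDA-MB-231 cells (Homo sapiens) for antiproliferative activity, read by MTT assay, with a stated time of 72 h; on this read-out higher numbers stand for weaker inhibition and lower numbers for stronger inhibition. For compound 1 the result is a limit of the assay, > 10000 nM. Compound 2 gives 2500 nM, which is an at least 4.0-fold lower number from compound 1 to compound 2 (0.60 log units; beyond the scatter). For compound 3 the result is again a limit, > 10000 nM. Compound 3 therefore stands at the weak end of what this assay can report, a position it shares with one other compound (the limit of > 10000 nM in this assay, at which 2 of the 3 values shown sit). The step of an at least 4.0-fold higher number from compound 2 to compound 3 (0.60 log units; beyond the scatter) shows that adding the chloro alone was enough to push the number back to the limit, while the step that the two limits leave unreadable from compound 1 to compound 3 cannot be sized.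

Compound 4 `CCNC(=O)Nc1ccc(S(=O)(=O)Nc2cccc(-c3nc(-c4ccc(NC(=O)c5cccnc5)cc4Cl)no3)c2)cc1` differs from compound 3 in 4-((ethylcarbamoyl)amino)phenyl in place of 4-acetamido-3-chlorophenyl on a sulfonyl sulfur. Within the data shown here, two things change at once: the chloro leaves, which reverses the change seen in an at least 4.0-fold higher number from compound 2 to compound 3 (0.60 log units; beyond the scatter), and the acetamido becomes an ethylurea, a change no measured pair covers. The expected direction is thus a lower number, roughly back toward compound 2, with the urea's contribution unknown. Compound 4 is expected to give 3000 nM, between 1000 nM and 10000 nM, a step of an at least 3.3-fold lower number from compound 3 to compound 4 (0.52 log units; beyond the scatter) that is expected to be at least modest.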

Compound 4, half-maximal inhibitory concentration: 3100 nM
Beside the measured number, compound 4's estimate is 1.0-fold (0.01 log units) below it; the range from low to high includes it.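

In this assay, ethylamino in place of methyl on the carbonyl carbon, which turns the acetamido into an ethylurea, gives a 1.2-fold higher number from compound 2 to compound 4 (0.09 log units; within the scatter), so the two groups cannot be told apart on this read-out. On the aromatic carbon that carries methyl in the least elaborated member of the set, (ethylcarbamoyl)amino gives an at least 3.2-fold lower number from compound 1 to compound 4 (0.50 log units; beyond the scatter), so two different groups, acetamido and this urea, now both give a lower number than methyl at this place. With 4-((ethylcarbamoyl)amino)phenyl in place of 4-acetamido-3-chlorophenyl on the sulfonyl sulfur, the result is an at least 3.2-fold lower number from compound 3 to compound 4 (0.50 log units; beyond the scatter), and this step and the one before give only minimum sizes because each starts from a compound at the limit: the limit of > 10000 nM in this assay, at which 2 of the 4 values shown sit.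

The compounds shown leave open whether a longer chain on the urea, such as propyl or butyl, or a plain amine in place of the urea, would keep the number near these values or move it. They also leave open whether chloro in place of hydrogen on the aromatic carbon of compound 4 would push the number back to the limit, as it does with the acetamido group.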